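A Hydroxy Group Added to Compound 1

A few compounds are considered here, and "the series" means these few. Any claim that something is new, unique, unknown or untested is made for them only; others in the source may bear on it.

Compound 1 `Cn1c(/C=C/C(=O)c2ccccc2)cc(Br)c1Br` offers no number to build on. In a functional assay on Caco-2 cells (Homo sapiens) for cytotoxicity, read by MTT assay, with stated times of 6 h and 48 h (on this read-out lower numbers stand for stronger inhibition and higher numbers for weaker inhibition), compound 1 gives >= 100000 nM, which is a limit of the assay. In this assay compound 2 `Cn1c(/C=C/C(=O)c2ccc[nH]2)cc(Br)c1Br` gives >= 100000 nM, also a limit. In this assay compound 3 `Cn1c(/C=C/C(=O)c2cccc(O)c2)cc(Br)c1Br` gives >= 100000 nM, again a limit. The whole series shown so far therefore comes down to the limit of >= 100000 nM in this assay, at which 3 of the 3 values shown sit.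

Compound 4 `Cn1c(/C=C/C(=O)c2ccc(O)cc2)cc(Br)c1Br` departs from compound 1 by a single change, hydroxy in place of hydrogen on an aromatic carbon, para to a large group: hydroxy in place of hydrogen on an aromatic carbon.

For the measured compounds named here, two measured steps bear on this change. The nearer one is the same kind of exchange, which gives a step that the two limits leave unreadable from compound 1 to compound 3. The other, 1H-pyrrol-2-yl in place of phenyl on a carbonyl carbon, gives a step that the two limits leave unreadable from compound 1 to compound 2. Neither step has a readable size, so neither indicates a direction, and no step beyond the scatter is expected in this assay. The expected change is a number no higher from compound 1 to compound 4 (the limit leaves the size open), and the assay will most likely again report only a limit. For compound 4 the estimated value is 100000 nM, with an expected range from 40000 nM to 200000 nM.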

Compound 4, half-maximal inhibitory concentration: 6000 nM
Estimate against measurement, compound 4: 17-fold (1.22 log units) above, and the stated range ends above it.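

In this assay, for the compounds shown here, hydroxy in place of hydrogen on an aromatic carbon, para to a large group, gives an at least 16-fold lower number from compound 1 to compound 4 (1.22 log units; beyond the scatter) and with it the first number that is not a limit. Compound 3 also carries a hydroxy group on that ring, and in this assay compound 3 gives >= 100000 nM as its value, which is a limit. The exchange therefore does not read the same at both places, with compound 3 going against any rule that a hydroxy group on this ring is enough for a readable number, and the size of the step stays open on one side because compound 1 rests on a limit, as most of the series does: the limit of >= 100000 nM in this assay, at which 3 of the 4 values shown sit.

The compounds shown leave open whether a methoxy group, an amine or a fluorine atom at this position would also give a readable number, or only the hydroxy group does. They also leave open whether compound 4 at 6000 nM owes anything to the bromine atoms on the shared core.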